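Toward the 2,6-dichlorobenzyl sulfanyl analogue of compound 1

The source may report more compounds than this note shows. Statements on the series, on what has been measured and on what is new or still open speak of the compounds shown alone.

Compound 1 `COc1cccc(CSc2nnc([C@@H](C)c3ccc4cc(OC)ccc4c3)n2-c2ccc(F)cc2)c1`: 211000 nM
Compound 2 `COc1ccc(CSc2nnc([C@@H](C)c3ccc4cc(OC)ccc4c3)n2-c2ccc(F)cc2)cc1`: 400000 nM
Compound 3 `COc1ccc2cc([C@H](C)c3nnc(SCc4c(C)cc(C)cc4C)n3-c3cccc(Cl)c3)ccc2c1`: 16300 nM

Of the compounds shown here, three have been measured in a functional assay on PC-3 cells (Homo sapiens) for cytotoxicity, read by MTT assay; on this read-out lower numbers stand for stronger inhibition and higher numbers for weaker inhibition. Compound 1 stands second highest of the three numbers; its nearest neighbour is compound 2, and its furthest is compound 3, whose number lies well beyond the scatter below that of compound 1. Compound 3 differs from compound 1 in two places at once, so its lower number cannot be laid at the door of either change alone.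

Compound 4 `COc1ccc2cc([C@H](C)c3nnc(SCc4c(Cl)cccc4Cl)n3-c3ccc(F)cc3)ccc2c1` is the new compound. It differs from compound 1 in one place: 2,6-dichlorophenyl in place of 3-methoxyphenyl on a saturated chain carbon bound to a sulfur.

For the measured compounds named here, only one single-point step is known, a 1.9-fold higher number from compound 1 to compound 2 (0.28 log units; within the scatter), and it moved the methoxy group around the ring rather than exchanging the ring's substituents, so it bears on compound 4 only loosely. Moving the methoxy group changed nothing beyond the scatter. Compound 3, which also carries a benzyl group with substituents on both sides of its point of attachment, gives a much lower number, but its different group on the nitrogen leaves that hint unconfirmed.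

The expectation for compound 4 is therefore a modestly lower number, a 3.0-fold lower number from compound 1 to compound 4 (0.48 log units; beyond the scatter), with wide uncertainty. In this assay compound 4 is estimated at 70000 nM, in the range 15000 nM to 300000 nM.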

Compound 4, half-maximal inhibitory concentration: 216000 nM
Compound 4: the middle estimate sits 3.1-fold (0.49 log units) below what was measured; the measured number falls inside the stated range.
By their numbers in this assay, from the lowest: compound 3; then compounds 1, 4 and 2 (each within the scatter of the next).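

In this assay, putting 2,6-dichlorophenyl in place of 3-methoxyphenyl on a saturated chain carbon bound to a sulfur gives a 1.0-fold higher number from compound 1 to compound 4 (0.01 log units; within the scatter) and, with 4-methoxyphenyl as the group replaced, a 1.9-fold lower number from compound 2 to compound 4 (0.27 log units; within the scatter) for the same kind of exchange. Earlier, this position had been tested only by moving the methoxy group around the ring, whereas compound 4 shows that exchanging the whole substitution of the ring, with two chlorines taking the place of the methoxy group and the hydrogen-bond acceptor of that group gone, also stays within the scatter. With the rest of compound 1 held fixed, the three groups tested at this position therefore cannot be told apart on this read-out, and nothing available explains why their numbers stay together.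

The compounds shown leave open whether either of the two places in which compound 3 differs from compound 1 accounts for the number of compound 3 on its own. They also leave open whether an amine or a carboxylic acid on the phenyl ring at this position, or a longer chain in place of the single saturated carbon bound to the sulfur, would shift the number beyond the scatter in this assay at all.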